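Trifluoromethyl for fluoro on compound 1

A few compounds are considered here, and "the series" means these few. Any claim that something is new, unique, unknown or untested is made for them only; others in the source may bear on it.

Compound 1 `CN1C/C(=C\c2cccnc2)C(=O)/C(=C/c2ccccc2F)C1` gives 15900 nM in the measured series
Compound 2 `CN1C/C(=C\c2cccnc2)C(=O)/C(=C/c2cc([N+](=O)[O-])ccc2F)C1` gives 15700 nM in the measured series

Within the data shown here, in an ADME assay on L02 cells (Homo sapiens) for cytotoxicity, read by MTT assay, with a stated time of 24 h (a lower number here means a stronger inhibitor, a higher number a weaker inhibitor), compound 1 gives 15900 nM and lies within the scatter of the only other measured compound. Compound 3 `CN1C/C(=C\c2cccnc2)C(=O)/C(=C/c2ccccc2C(F)(F)F)C1` carries trifluoromethyl in place of fluoro on an aromatic carbon, ortho to a large group (trifluoromethyl in place of fluoro on an aromatic carbon). Among the measured compounds shown here, the one measured step (a 1.0-fold lower number from compound 1 to compound 2 (0.01 log units; within the scatter)) is a nitro in place of hydrogen, keeps the fluoro and bears only loosely on this change. No step beyond the scatter is therefore expected in this assay for this swap. Compound 3 is estimated at 15000 nM with an expected range of 7000 nM to 32000 nM as its limits. The estimated move is a 1.1-fold lower number from compound 1 to compound 3 (0.03 log units; within the scatter) and no more.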

Compound 3, half-maximal inhibitory concentration: 14100 nM
Compound 3: middle estimate off by 1.1-fold (0.03 log units), on the high side; the range from low to high includes it.
By their numbers in this assay, from the lowest: compounds 3, 2 and 1 (each within the scatter of the next).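

In this assay, trifluoromethyl in place of fluoro on an aromatic carbon, ortho to a large group, gives a 1.1-fold lower number from compound 1 to compound 3 (0.05 log units; within the scatter). Among these compounds, compounds 1 and 2 both kept the fluoro, so this is the first sign that the reading survives its replacement, here by a larger group, without a step beyond the scatter. No measurement at hand accounts for this result. On these data alone, whether an amine or a carboxylic acid on this aromatic carbon would give a step beyond the scatter remains open.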